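The source may report more compounds than this note shows. Statements on the series, on what has been measured and on what is new or still open speak of the compounds shown alone.

Going by the values given here, in a functional assay on HepG2 cells (Homo sapiens) for inhibition, read by MTT assay, with a stated time of 72 h (a lower number here means that less compound is needed, a higher number that more compound is needed for the effect), compound 1 `CC1(C)CCC[C@]2(C)[C@@H](Cc3ccc(O)cc3O)[C@](C)(O)CC[C@@H]12` gives 10200 nM, the only actual number so far. Compound 2 `CC1(C)CCC[C@]2(C)[C@@H](Cc3cc(O)ccc3O)[C@](C)(O)CC[C@@H]12` shows > 50000 nM, which is a limit. Compound 3 `Cc1cc(O)cc(O)c1C[C@@H]1[C@@]2(C)CCCC(C)(C)[C@@H]2CC[C@@]1(C)O` keeps the core of compound 1 with one change, methyl in place of hydrogen on an aromatic carbon. Among the compounds with values here, the only measured step, an at least 4.9-fold higher number from compound 1 to compound 2 (0.69 log units; beyond the scatter), swaps the dihydroxyphenyl pattern and adds no methyl, so it shows that this ring can matter but gives no size for this change. No shift beyond the scatter is therefore expected, with the estimated step being a 1.2-fold higher number from compound 1 to compound 3 (0.07 log units; within the scatter). For compound 3, the estimated value is 12000 nM, within a range of 4500 nM to 35000 nM.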

Compound 3, half-maximal effective concentration: 11100 nM
Compound 3: the middle estimate sits 1.1-fold (0.03 log units) above what was measured; low and high end bracket the measured number.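

Methyl in place of hydrogen on this aromatic carbon, ortho to a large group and meta to two hydroxy groups, gives a 1.1-fold higher number from compound 1 to compound 3 (0.04 log units; within the scatter) in this assay. Going by these compounds alone, this position therefore accepts a methyl with no shift beyond the scatter, whereas the earlier compounds showed only that the hydroxy pattern on this ring can matter. Nothing at hand accounts for this result.

Going by these compounds, whether an ethyl, an amine or a carboxylic acid on this carbon would leave the number within the scatter remains open. So does whether a methyl would act alike on the ring of compound 2.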